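Thiol Analogue of a Series Without Measurable Cytotoxicity

The source may hold more compounds than are shown below. What is called first, only, known or untested is meant among the compounds shown, and "the series" means these compounds.

Compound 3 `COc1ccc(CNc2nc(SC)nc3ccccc23)cc1` belongs to a small set of three measured compounds alongside compound 1 `COc1ccc(CNc2nc([Se]C)nc3ccccc23)cc1` and compound 2 `COc1ccc(CNc2nc([SeH])nc3ccccc23)cc1`. In a functional assay on HT-29 cells (Homo sapiens) for cytotoxicity, read by MTT assay, with a stated time of 72 h (a lower number here means that less compound is tolerated, a higher number that more compound is tolerated), compound 1 gives > 100000 nM, which is a limit of the assay and not a number. In this assay compound 2 gives > 100000 nM, again a limit. In this assay compound 3 gives > 100000 nM, also a limit. Compound 3 therefore stands where both of its relatives stand, at the limit of > 100000 nM in this assay, at which 3 of the 3 values shown sit, and no ordering among the three can be read.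

Compound 4 `COc1ccc(CNc2nc(S)nc3ccccc23)cc1` is not yet measured. It differs from compound 3 by hydrogen in place of methyl on a sulfur; the same difference, cut one bond further out, reads methylsulfanyl to sulfanyl. The closest parallel among the measured steps is the one in which hydrogen replaced methyl on a selenium, a step that the two limits leave unreadable from compound 1 to compound 2. The step that the two limits leave unreadable from compound 1 to compound 3 and the step that the two limits leave unreadable from compound 2 to compound 3 are likewise unreadable. With every measured value sitting at the limit, no step size can be derived, and compound 4 is expected to fall at or beyond that limit as well, with no step beyond the scatter expected in this assay. Compound 4 is estimated at 200000 nM, with a range from 50000 nM to 1000000 nM. The step from compound 3 to compound 4 that this estimate means is expected to be a step that the limit leaves unreadable from compound 3 to compound 4.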

Compound 4, concentration lethal to 50% of the cells: 63900 nM
Estimate against measurement, compound 4: 3.1-fold (0.50 log units) above; low and high end bracket the measured number.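

Hydrogen in place of methyl on the sulfur gives the first readable step in the set, an at least 1.5-fold lower number from compound 3 to compound 4 (0.19 log units; that floor lies within the scatter), in this assay, whereas the matching exchange on a selenium and the other earlier steps cannot be read. Set against the selenium relatives, the sulfanyl group gives an at least 1.5-fold lower number from compound 2 to compound 4 (0.19 log units; that floor lies within the scatter), and the replacement of the whole methylselanyl group on the aromatic carbon gives an at least 1.5-fold lower number from compound 1 to compound 4 (0.19 log units; that floor lies within the scatter), so all three steps have floors that stay within the scatter and none establishes a real change on its own. What is new at this position is that one compound now carries a value that is not a limit, while the other compounds remain at one: the limit of > 100000 nM in this assay, at which 3 of the 4 values shown sit.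

On these data alone, the true size of all three steps stays open, since each starts from a compound that has only a limit. Also open, as far as these compounds go, is how this assay would read with an amine, a hydroxyl group or a longer chain such as ethylsulfanyl on the same aromatic carbon of the shared core.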